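The compounds below may be only part of what the source reports. "The series", "measured", "known", "first", "only" and "open" are said of these compounds alone.

Measured compounds:
- compound 1, `CCCCCCCCNC(=O)/C=C/c1c(/C=C/c2ccc(OC)cc2)cc(OC)cc1OC`, 8060 nM in a functional assay on B16-F10 cells (Mus musculus) for inhibition, read by MTT assay, with a stated time of 48 h; on this read-out higher numbers stand for weaker inhibition and lower numbers for stronger inhibition
- compound 2, `COc1ccc(/C=C/c2cc(OC)cc(OC)c2/C=C/C(=O)N2CCC(Cl)CC2)cc1`, 4690 nM in this assay

Compound 1 carries an octyl chain on its amide nitrogen and gives the higher of the two numbers in this assay, though its gap to compound 2 is small: a 1.7-fold lower number from compound 1 to compound 2 (0.24 log units; within the scatter). Compound 3, `COc1ccc(/C=C/c2cc(OC)cc(OC)c2/C=C/C(=O)Nc2cc(OC)c(OC)c(OC)c2)cc1`, has not yet been measured in this assay. It differs from compound 1 by 3,4,5-trimethoxyphenyl in place of octyl on an amide-type nitrogen.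

Among the measured compounds shown here, the only measured step that bears on this change is the one from compound 1 to compound 2, which also replaced the group on the amide side of the carbonyl, and it stayed within the scatter. Nothing else among these compounds tests a trimethoxyphenyl at this position. The step to compound 3 is therefore expected to be small, a 1.5-fold lower number from compound 1 to compound 3 (0.17 log units; within the scatter), with no clear direction beyond the scatter. Compound 3 is estimated at 5500 nM in this assay, within a range of 1500 nM to 18000 nM.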

Compound 3, half-maximal inhibitory concentration: 8150 nM
For compound 3 the middle estimate is 1.5-fold (0.17 log units) below the measured one; the measured number falls inside the stated range.
By their numbers in this assay, from the lowest: compounds 2, 1 and 3 (each within the scatter of the next).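

Putting 3,4,5-trimethoxyphenyl in place of octyl on the amide-type nitrogen gives a 1.0-fold higher number from compound 1 to compound 3 (0.00 log units; within the scatter) in this assay. The earlier step showed only that 4-chloropiperidin-1-yl could replace the octylamino group with a result within the scatter; this one shows that the numbers also cannot be told apart when a chain with no ring and no hydrogen-bond acceptors gives way to a six-membered aromatic ring with hydrogen-bond acceptors. No measurement here explains this flat result.

From the compounds shown here alone, it remains open whether any group on this nitrogen can take the number beyond the scatter. A plain phenyl, a carboxylic acid or a shorter chain such as ethyl could each test this, and the plain phenyl would also show what the methoxy groups contribute.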